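The compounds below may be only part of what the source reports. "The series", "measured", "known", "first", "only" and "open" are said of these compounds alone.

Compound 1 `COc1ccc(Cl)cc1S(=O)(=O)Nc1cncc(C(=O)N2CCN(C)CC2)c1` gives 671 nM in an assay on isolated protein for inhibition of alkaline phosphatase, tissue-nonspecific isozyme (Homo sapiens); on this read-out lower numbers stand for stronger inhibition and higher numbers for weaker inhibition.
Compound 2 `COc1ccc(Cl)cc1S(=O)(=O)Nc1cncc(-c2ccc(C)cc2)c1` gives 147 nM in this assay.

Among the two numbers on hand, compound 2 holds the lowest; its only neighbour is compound 1, and the step of a 4.6-fold lower number from compound 1 to compound 2 (0.66 log units; beyond the scatter) separates the two beyond the scatter. Compound 3 `COc1ccc(Cl)cc1S(=O)(=O)Nc1cncc(-c2ccc(Cl)cc2)c1` differs from compound 2 by chloro in place of methyl on an aromatic carbon. Among the compounds with values here, no measured step bears directly on this change. Within the data shown here, the single measured step, a 4.6-fold lower number from compound 1 to compound 2 (0.66 log units; beyond the scatter), exchanges an entire substituent on the shared core and brings in the 4-methylphenyl group that compound 3 retains, now carrying chloro in place of methyl; it is a far larger rearrangement than the one-atom swap at hand and gives no direction for it. With nothing measured to point one way or the other, a step in this assay of small size is expected, in either direction and most likely within the scatter. Compound 3 is therefore estimated at 130 nM, with a range from 50 nM to 350 nM, so that the expected step is a 1.1-fold lower number from compound 2 to compound 3 (0.05 log units; within the scatter).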

Compound 3, half-maximal inhibitory concentration: 198 nM
Compound 3: middle estimate off by 1.5-fold (0.18 log units), on the low side; measured number inside the range.
By their numbers in this assay, from the lowest: compounds 2 and 3 (each within the scatter of the next); then compound 1.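

In this assay, methyl and chloro at this place, para to a large group, cannot be told apart: a 1.3-fold higher number from compound 2 to compound 3 (0.13 log units; within the scatter) stays within the scatter, so this exchange of one heavy atom for another gives no readable preference between the two groups. The advantage over the (4-methylpiperazin-1-yl)carbonyl group is therefore not tied to the methyl, since a 3.4-fold lower number from compound 1 to compound 3 (0.53 log units; beyond the scatter) lies beyond the scatter and 4-chlorophenyl stands on the same side of compound 1 as 4-methylphenyl does. Nothing on hand explains why either group behaves as it does in this assay.

Within the data shown here, with only two groups tried at this place, and those two indistinguishable, it remains open whether any substituent there matters at all, and whether an unsubstituted phenyl, a methoxy, an amine or a carboxylic acid on the same ring would leave the number where it is or move it beyond the scatter. Also open, as far as these compounds go, is how much of the gain over compound 1 comes from the phenyl ring itself, which a pyridine, a cyclohexyl ring or a simple n-propyl chain in its place could begin to answer.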